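Shortening the selenium-bound chain of compound 2

The source may report more compounds than this note shows. Statements on the series, on what has been measured and on what is new or still open speak of the compounds shown alone.

Two measured members exist: compound 1 `CCCCC[Se]c1nc([Se]CCCCC)c2ccccc2n1` and compound 2 `CCCCC[Se]c1nc(NCc2ccccc2)c2ccccc2n1`. Among the measured compounds shown here, in a functional assay on MCF7 cells (Homo sapiens) for cytotoxicity, read by MTT assay, with a stated time of 72 h (a lower number here means a stronger inhibitor of growth, a higher number a weaker inhibitor of growth), compound 1 gives 95100 nM, and compound 2 gives 47100 nM, the lowest of the two numbers; its only neighbour is reached by a 2.0-fold lower number from compound 1 to compound 2 (0.31 log units; beyond the scatter). Compound 3 `C[Se]c1nc(NCc2ccccc2)c2ccccc2n1` is the next to be measured and differs from compound 2 by hydrogen in place of butyl on a saturated chain carbon bound to a selenium atom, which cut one bond further out reads pentyl to methyl. For the measured compounds named here, the single measured step, a 2.0-fold lower number from compound 1 to compound 2 (0.31 log units; beyond the scatter), exchanges a whole selenium-bound group for a nitrogen-linked ring group and says nothing about shortening the chain that stays; no measured step bears on this change directly. A step within the scatter is therefore expected in this assay, with no settled direction, a 1.1-fold higher number from compound 2 to compound 3 (0.03 log units; within the scatter). Compound 3 is estimated at 50000 nM, in a range from 20000 nM to 125000 nM.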

Compound 3, concentration for total growth inhibition: 67000 nM
The estimate for compound 3 lay 1.3-fold (0.13 log units) below the measured number; the range from low to high includes it.
By their numbers in this assay, from the lowest: compounds 2, 3 and 1 (each within the scatter of the next, the first and the last beyond it).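

Among the compounds shown here, the selenium-bound chain is varied on its own for the first time with compound 3, and in this assay the exchange of pentyl for methyl gives a 1.4-fold higher number from compound 2 to compound 3 (0.15 log units; within the scatter). Loss of the butyl portion therefore leaves compound 2 and compound 3 unseparated in this assay, something the earlier step could not show, since that step replaced a whole selenium-bound group on the other side of the core. Nothing available accounts for this result.

With only pentyl and methyl at this position, the compounds shown leave open whether a propyl or a longer chain such as octyl would read the same. They also leave open whether a carboxylic acid or an amine at the end of the chain would move the number beyond the scatter.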